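Working notes: the step from compound 3 to compound 4

The source may hold more compounds than are shown below. What is called first, only, known or untested is meant among the compounds shown, and "the series" means these compounds.

- compound 1 `CC(=O)N[C@@H]1CCC[C@H](C(=O)Nc2cc(-c3cnn(C)c3C)c(Cl)cn2)C1` gives 960000 nM
- compound 2 `CC(=O)N[C@@H]1CCC[C@H](C(=O)Nc2cc(-c3cnn4c3CCC4)c(Cl)cn2)C1` gives 160000 nM
- compound 3 `CC(=O)N[C@@H]1CCC[C@H](C(=O)Nc2cc(-c3cnn4c3CN(C)CC4)c(Cl)cn2)C1` gives 870000 nM

In a physicochemical assay for solubility, in phosphate buffer, at pH 7.4 (a higher number here means a more soluble compound, a lower number a less soluble compound), compound 3 stands level with the higher of the other two values (a 1.1-fold lower number from compound 1 to compound 3 (0.04 log units; within the scatter)) and well clear of the lower (a 5.4-fold higher number from compound 2 to compound 3 (0.74 log units; beyond the scatter)). Compound 4 `CC(=O)N[C@@H]1CCC[C@H](C(=O)Nc2cc(-c3cnn4c3CC(C)(C)C4)c(Cl)cn2)C1` brings this change: a group of 10 heavy atoms (8 carbon, 2 nitrogen; one five-membered non-aromatic ring with 1 hetero atom, one five-membered aromatic ring with 2 hetero atoms) in place of a group of 10 heavy atoms (7 carbon, 3 nitrogen; one five-membered aromatic ring with 2 hetero atoms, one six-membered non-aromatic ring with 2 hetero atoms), on an aromatic carbon on an aromatic carbon, ortho to a chloro group. Compound 4 shares the five-membered non-aromatic ring with 1 hetero atom of compound 2, so the closest guide is that second step read in reverse, and the modest step (a 6.0-fold lower number from compound 1 to compound 2 (0.78 log units; beyond the scatter)) runs the same way. A drop beyond the scatter is expected (a 7.9-fold lower number from compound 3 to compound 4 (0.90 log units; beyond the scatter)). For compound 4 the estimate is 110000 nM with an expected range of 35000 nM to 300000 nM in this read-out.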

Compound 4, solubility: 150000 nM
Compound 4: the middle estimate sits 1.4-fold (0.13 log units) below what was measured, and the stated range covers the measured number.
By their numbers in this assay, from the lowest: compounds 4 and 2 (each within the scatter of the next); then compounds 3 and 1 (each within the scatter of the next).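

In this assay, adding methyl groups to the five-membered non-aromatic ring with 1 hetero atom leaves the read-out level (a 1.1-fold lower number from compound 2 to compound 4 (0.03 log units; within the scatter)). Reaching this group from the six-membered non-aromatic ring with 2 hetero atoms gives a step beyond the scatter (a 5.8-fold lower number from compound 3 to compound 4 (0.76 log units; beyond the scatter)), as does reaching it from the unfused group (a 6.4-fold lower number from compound 1 to compound 4 (0.81 log units; beyond the scatter)). Among these compounds, both carrying the five-membered non-aromatic ring sit lower, and none goes against this.

No measurement here bears on the cause. Open, as far as these compounds go, is whether an amine or carboxylic acid on that ring, in place of the methyl groups, would shift the read-out.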